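This account rests on a few compounds, and the source may have more. Where it says the series, first, only, none or still open, it means among the compounds named here.

Compound 1 `COc1ccc2nc(C)cc(OCC(=O)Nc3c(C)cccc3C)c2c1` is tested in a toxicity assay on HepG2 cells (Homo sapiens) for inhibition, read by CellTiter-Glo, with a stated time of 48 h; on this read-out higher numbers stand for weaker inhibition and lower numbers for stronger inhibition; in that assay compound 1 gives only a limit of the assay, > 100000 nM. Compound 2 `COc1ccc2nc(C)cc(OCC(=O)Nc3nc(C)c(C)s3)c2c1` gives in this assay likewise only a limit, > 100000 nM. The step from compound 1 to compound 2, a step that the two limits leave unreadable from compound 1 to compound 2, is therefore unreadable, its size not known, both ends sitting at the limit of > 100000 nM in this assay, at which 2 of the 2 values shown sit. Compound 3 `COc1ccc2nc(C)cc(OCC(=O)NC3CONC3=O)c2c1` has not yet been measured. It differs from compound 2 in a group of 6 heavy atoms (3 carbon, 1 nitrogen, 2 oxygen; one five-membered non-aromatic ring with 2 hetero atoms) in place of a group of 7 heavy atoms (5 carbon, 1 nitrogen, 1 sulfur; one five-membered aromatic ring with 2 hetero atoms), on an amide-type nitrogen. Going by the values given here, the one measured step, a step that the two limits leave unreadable from compound 1 to compound 2, bears on it as another change on the same amide-type nitrogen, yet it gives no size. Compound 2 stands at the limit, and no step beyond the scatter is expected in this assay from this change in either direction. Compound 3 is thus expected to reach only the limit as well, an estimate of 100000 nM with a range from 30000 nM to 300000 nM. The step expected from that estimate is a number no higher from compound 2 to compound 3 (the limit leaves the size open).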

Compound 3, half-maximal inhibitory concentration: > 100000 nM
Compound 3: a limit, no number (the forecaster's own chance of this, stated with the estimate: 85%); the middle value lies on the limit itself.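

Compound 1, compound 2 and compound 3 each give only a limit in this assay, so no step among them can be read: the limit of > 100000 nM in this assay, at which 3 of the 3 values shown sit.

The compounds shown leave open how strongly any of them inhibits and whether the group on the amide-type nitrogen changes that inhibition.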